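A few compounds are considered here, and "the series" means these few. Any claim that something is new, unique, unknown or untested is made for them only; others in the source may bear on it.

Working notes on the series sharing one core, read in a functional assay on MCF7 cells (Homo sapiens) for inhibition, read by MTT assay; on this read-out higher numbers stand for weaker inhibition and lower numbers for stronger inhibition. Compound 1 (`CCc1ccc(C(=O)Nc2ccc(Nc3ncnc4cc(OC)c(OC)cc34)cc2)cc1`) gives 65000 nM, compound 2 (`COc1cc2ncnc(Nc3ccc(NC(=O)c4cccc(F)c4)cc3)c2cc1OC`) gives 13600 nM, and compound 3 (`COc1cc2ncnc(Nc3ccc(NC(=O)c4cccc(Cl)c4)cc3)c2cc1OC`) gives 18000 nM. Compound 3 cannot be told apart from compound 2, with a 1.3-fold higher number from compound 2 to compound 3 (0.12 log units; within the scatter), and it lies clearly under compound 1.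

The unmeasured compound 4 (`COc1cc2ncnc(Nc3ccc(NC(=O)c4ccc(Br)cc4)cc3)c2cc1OC`) has 4-bromophenyl in place of 3-chlorophenyl on a carbonyl carbon. Among the measured compounds shown here, no measured step makes this exact change, so the evidence is indirect. The swap of chloro for fluoro, a 1.3-fold higher number from compound 2 to compound 3 (0.12 log units; within the scatter), suggests that exchanging one halogen for another need not shift the number. The only measured 4-substituted phenyl is the 4-ethylphenyl of compound 1, and replacing it gave a 4.8-fold lower number from compound 1 to compound 2 (0.68 log units; beyond the scatter) and a 3.6-fold lower number from compound 1 to compound 3 (0.56 log units; beyond the scatter), both modest. Those steps change the group as well as its place, so they cannot separate the two.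

In this assay, a step no larger than the scatter is therefore expected, leaning towards a higher number. The estimated step is a 1.4-fold higher number from compound 3 to compound 4 (0.16 log units; within the scatter). Compound 4 is estimated at 26000 nM, with an expected range of 9000 nM to 70000 nM.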

Compound 4, half-maximal inhibitory concentration: 43000 nM
Compound 4: the middle estimate sits 1.7-fold (0.22 log units) below what was measured; the range from low to high includes it.
By their numbers in this assay, from the lowest: compounds 2 and 3 (each within the scatter of the next); then compounds 4 and 1 (each within the scatter of the next).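

Within the 3-substituted phenyls, exchanging one halogen for another left the number unresolved, but on this carbonyl carbon 4-bromophenyl does move it in this assay, with a 2.4-fold higher number from compound 3 to compound 4 (0.38 log units; beyond the scatter) and a 3.2-fold higher number from compound 2 to compound 4 (0.50 log units; beyond the scatter), both modest. Compound 4 also cannot be told apart from the only other 4-substituted phenyl in the series, with a 1.5-fold lower number from compound 1 to compound 4 (0.18 log units; within the scatter), so the four compounds fall into two groups: compounds 2 and 3 with the 3-halophenyls at the lower numbers, and compounds 1 and 4 with the 4-substituted phenyls at the higher numbers, and none of the four goes against this split. No evidence in hand bears on what lies behind this split.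

Every step between the two groups changes the substituent and its place on the phenyl together, so a matched pair such as 3-bromophenyl against 4-bromophenyl, or 3-chlorophenyl against 4-chlorophenyl, is needed to show which of the two carries the shift. Also open, as far as these compounds go, is how the unsubstituted phenyl, or a phenyl bearing an amine or a carboxylic acid, would read on this carbonyl carbon.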